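Kinetic solubility in a sulfonamide series: pyridyl isomer swap

The source may report more compounds than this note shows. Statements on the series, on what has been measured and on what is new or still open speak of the compounds shown alone.

Measured compounds in a physicochemical assay for solubility, read by HPLC, using the shake flask method, measured as kinetic solubility, with a stated time of 20 h, at pH 6.5, tested at 200 uM; a lower number here means a less soluble compound, a higher number a more soluble compound:
Compound 1 `O=S(=O)(NCC1COC1)c1cccc(-c2ccc3nccc(-c4ccncc4)c3n2)c1`: 20000 nM
Compound 3 `O=S(=O)(c1cccc(-c2ccc3nccc(-c4ccncc4)c3n2)c1)N1CC[C@H](O)C1`: 20000 nM
Compound 2 `NS(=O)(=O)c1cccc(-c2ccc3nccc(-c4ccncc4)c3n2)c1`: only a limit, < 5000 nM

Compound 2 stands at the limit of this assay, (the limit of < 5000 nM in this assay, at which 1 of the 3 values shown sits); no number is known for it. Its neighbours show that the steps of an at least 4.0-fold lower number from compound 1 to compound 2 (0.60 log units; beyond the scatter) and an at least 4.0-fold higher number from compound 2 to compound 3 (0.60 log units; beyond the scatter) are each at least modest, while no change at the digits printed from compound 1 to compound 3 (within the scatter). Compound 4 `NS(=O)(=O)c1cccc(-c2ccc3nccc(-c4cccnc4)c3n2)c1` differs from compound 2 by pyridin-3-yl in place of pyridin-4-yl on an aromatic carbon. For the measured compounds named here, none of the measured steps touches this part of the shared core; all three alter the sulfonamide side of the molecule. So no measured step informs this change, and none beyond the scatter is expected in this assay: the step that the limit leaves unreadable from compound 2 to compound 4 is the expectation. Compound 4 is estimated at 4000 nM, between 1500 nM and 12000 nM, most likely again reported only as a limit.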

Compound 4, solubility: < 5000 nM
Compound 4: no number, only a limit (the forecaster's own chance of this, stated with the estimate: 65%); the middle value does not contradict the limit.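

For the compounds shown here, compound 2 and compound 4 both stand only as limits, so no step between them can be read: the limit of < 5000 nM in this assay, at which 2 of the 4 values shown sit. The compounds shown leave open what number either would carry, and whether pyridin-3-yl in place of pyridin-4-yl changes it.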